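This account rests on a few compounds, and the source may have more. Where it says the series, first, only, none or still open, it means among the compounds named here.

Compound 1 `Cc1ccc(S(=O)(=O)Nc2ccc(-c3nc4ccccc4o3)cc2)cc1`: in an assay on cells for inhibition of HSP60/HSP10 (Homo sapiens), with a stated time of 60 min (on this read-out lower numbers stand for stronger inhibition and higher numbers for weaker inhibition), compound 1 gives > 100000 nM, a limit of the assay rather than a number.
Compound 2 `COc1ccccc1S(=O)(=O)Nc1ccc(-c2nc3ccccc3o2)cc1`: compound 2 gives > 100000 nM, again a limit.
Compound 3 `O=S(=O)(Nc1ccc(-c2nc3ccccc3o2)cc1)c1ccc(F)cc1`: compound 3 gives 73000 nM.

Among the compounds with values here, compound 3 is thus the only compound of the three with a measured number in this assay; the other two stopped at the limit of > 100000 nM in this assay, at which 2 of the 3 values shown sit. Compound 4 `COc1ccc(Cl)cc1S(=O)(=O)Nc1ccc(-c2nc3ccccc3o2)cc1` differs from compound 3 in a single place: 5-chloro-2-methoxyphenyl in place of 4-fluorophenyl on a sulfonyl sulfur. This brings back the methoxyphenyl sulfonyl group of compound 2, now carrying an added chloro. Within the data shown here, two measured steps bear on the change. The step of an at least 1.3-fold lower number from compound 2 to compound 3 (0.13 log units; that floor lies within the scatter) runs in the opposite direction to the one now taken, so reversing it points toward a higher number. The step of an at least 1.3-fold lower number from compound 1 to compound 3 (0.13 log units; that floor lies within the scatter) is of the same minimal size and also leaves compound 3 as the weakest-numbered point. As far as these compounds go, both steps are floors set by a limit, so their true size is unknown; what is known is that the aryl sulfonyl group of compound 3 is the only one of the three to yield a number at all. For compound 4 the number is therefore expected to move upward, with the step of a 1.4-fold higher number from compound 3 to compound 4 (0.14 log units; within the scatter), and a return to the limit is a real possibility. Compound 4 is estimated at 100000 nM, within a range of 25000 nM to 400000 nM.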

Compound 4, half-maximal inhibitory concentration: > 100000 nM
Compound 4: a limit, no number; the forecaster's own chance of this, stated with the estimate: 55%; the middle value sits exactly at the limit.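

Compound 4 in this assay gives > 100000 nM, which is a limit and not a number. As far as these compounds go, putting 5-chloro-2-methoxyphenyl in place of 4-fluorophenyl on the sulfonyl sulfur gives an at least 1.3-fold higher number from compound 3 to compound 4 (0.13 log units; that floor lies within the scatter), so this floor alone does not separate the two compounds, and the true size of the change stays unknown. The steps linking compound 4 to compound 1 and compound 2 cannot be read, since both ends of each are limits, and adding a chloro to the methoxyphenyl group of compound 2 therefore did not yield a number in this series, leaving compound 3 as the only compound with one: the limit of > 100000 nM in this assay, at which 3 of the 4 values shown sit.

From the compounds shown here alone, how far compound 1, compound 2 and compound 4 lie past that limit remains open, so they cannot be ranked against each other or against compound 3. Going by these compounds, it also remains open whether another group on the sulfonyl sulfur, such as a phenyl ring carrying an amine or a carboxylic acid, would give a number clearly lower than that of compound 3.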